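Changing the Aryl Group of Compound 3

The source may hold more compounds than are shown below. What is called first, only, known or untested is meant among the compounds shown, and "the series" means these compounds.

Of the compounds shown here, three sharing one core have been tested in a functional assay on PC-3 cells (Homo sapiens) for inhibition; a lower number here means a stronger inhibitor, a higher number a weaker inhibitor. Compound 1 `Cc1ccc(O)c(/C=N\NC(=O)c2oc3cccc(O)c3c2C)c1` gives 7350 nM. Compound 3 `Cc1c(C(=O)N/N=C\c2cccc(O)c2)oc2cccc(O)c12` gives 17600 nM, the highest of the two plain numbers, and the step of a 2.4-fold higher number from compound 1 to compound 3 (0.38 log units; beyond the scatter) separates it from compound 1. For compound 2 `Cc1c(C(=O)N/N=C\c2ccco2)oc2cccc(O)c12` the result is only a limit of the assay, >= 40000 nM (the limit of >= 40000 nM in this assay, at which 1 of the 3 values shown sits). The steps of an at least 5.4-fold higher number from compound 1 to compound 2 (0.73 log units; beyond the scatter) and an at least 2.2-fold lower number from compound 2 to compound 3 (0.35 log units; beyond the scatter) show that both phenyl-bearing compounds give lower numbers than compound 2 does.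

Compound 4 `Cc1c(C(=O)N/N=C\c2cc(F)ccc2O)oc2cccc(O)c12` has not yet been measured. It differs from compound 3 in one place: 5-fluoro-2-hydroxyphenyl in place of 3-hydroxyphenyl on a carbon with a double bond to nitrogen. The incoming group resembles the 2-hydroxy-5-methylphenyl of compound 1, with fluorine in place of the methyl of compound 1. Among the measured compounds shown here, the only measured step that bears on this change is a 2.4-fold higher number from compound 1 to compound 3 (0.38 log units; beyond the scatter), which ran the other way when 2-hydroxy-5-methylphenyl was exchanged for 3-hydroxyphenyl. Because the step of a 2.4-fold higher number from compound 1 to compound 3 (0.38 log units; beyond the scatter) is largely undone here, compound 4 is expected to give a modestly lower number than compound 3, about a 2.2-fold lower number from compound 3 to compound 4 (0.34 log units; beyond the scatter). Compound 4 is therefore estimated at 8000 nM, with a likely range from 3000 nM to 25000 nM.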

Compound 4, half-maximal inhibitory concentration: 3170 nM
Compound 4: middle estimate off by 2.5-fold (0.40 log units), on the high side, within the range that was stated.
By their numbers in this assay, from the lowest: compound 4; then compound 1; then compound 3. At a limit, above all of these: compound 2.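

In this assay, exchanging 3-hydroxyphenyl for 5-fluoro-2-hydroxyphenyl on the carbon with a double bond to nitrogen gives a 5.6-fold lower number from compound 3 to compound 4 (0.74 log units; beyond the scatter), so the aryl group at this position can shift the result well beyond the scatter, and this exchange gives the lowest number of the series. The comparison with the methyl analogue adds something new: fluoro in place of methyl on an aromatic carbon gives a 2.3-fold lower number from compound 1 to compound 4 (0.37 log units; beyond the scatter), which shows that the result depends on this small group as well as on the hydroxyl-bearing ring around it. Against the furan-2-yl analogue, the new group gives an at least 12-fold lower number from compound 2 to compound 4 (1.10 log units; beyond the scatter), a step that rests on compound 2, whose result is a limit of the assay: the limit of >= 40000 nM in this assay, at which 1 of the 4 values shown sits.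

Compound 3 and compound 4 differ in both the placing of the hydroxyl and the presence of the fluoro group, so these two contributions cannot be separated here; a plain 2-hydroxyphenyl group would be needed to tell them apart. From the compounds shown here alone, it also remains open how chloro or methoxy would compare with fluoro and methyl in the same place, and the numbers alone do not explain why fluoro gives the lower value.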